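Five-membered ring swap on the shared core

The source may hold more compounds than are shown below. What is called first, only, known or untested is meant among the compounds shown, and "the series" means these compounds.

In a functional assay on HCT-116 cells (Homo sapiens), read by MTT assay, with a stated time of 72 h (on this read-out lower numbers stand for stronger inhibition and higher numbers for weaker inhibition), compound 2 `COc1ncnc2c1c(-c1ccoc1)cn2[C@@H]1O[C@H](CO)[C@@H](O)[C@H]1O` gives 130 nM, the lowest of the two numbers shown. Compound 1 `COc1ncnc2c1c(-c1ccsc1)cn2[C@@H]1O[C@H](CO)[C@@H](O)[C@H]1O` gives 140 nM in this assay, and the step of a 1.1-fold lower number from compound 1 to compound 2 (0.03 log units; within the scatter) lies within the scatter. Compound 3 `Cc1ncnc2c1c(-c1ccoc1)cn2[C@@H]1O[C@H](CO)[C@@H](O)[C@H]1O` gives > 20000 nM in this assay, a limit of the assay and not a number. The step of an at least 150-fold higher number from compound 2 to compound 3 (2.18 log units; beyond the scatter) is large. Compound 4 `COc1ncnc2c1c(-c1cccs1)cn2[C@@H]1O[C@H](CO)[C@@H](O)[C@H]1O` differs from compound 2 by thiophen-2-yl in place of furan-3-yl on an aromatic carbon. Among the measured compounds shown here, only the step from compound 1 to compound 2 bears on this change, and it stayed within the scatter; the move of the attachment point on the five-membered ring has no measured counterpart here. The expectation is therefore a step of no size beyond the scatter, a 1.2-fold higher number from compound 2 to compound 4 (0.06 log units; within the scatter). Compound 4 is expected to give 150 nM, with a range from 50 nM to 500 nM.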

Compound 4, half-maximal inhibitory concentration: 440 nM
For compound 4 the middle estimate is 2.9-fold (0.47 log units) below the measured one; measured number inside the range.
By their numbers in this assay, from the lowest: compounds 2 and 1 (each within the scatter of the next); then compound 4. At a limit, above all of these: compound 3.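

In this assay, the attachment point on the five-membered ring changes the number, where the exchange of sulfur for oxygen alone did not: thiophen-2-yl in place of thiophen-3-yl gives a 3.1-fold higher number from compound 1 to compound 4 (0.50 log units; beyond the scatter), with only the attachment point differing. Against the furan-3-yl group, thiophen-2-yl gives a 3.4-fold higher number from compound 2 to compound 4 (0.53 log units; beyond the scatter), also modest and beyond the scatter. Nothing measured here accounts for this shift.

Open remain furan-2-yl and phenyl on this aromatic carbon, and whether either stays with compound 2 or moves towards compound 4.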